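Removal of the ethyl group from compound 1

The source may hold more compounds than are shown below. What is called first, only, known or untested is meant among the compounds shown, and "the series" means these compounds.

In a functional assay on the whole organism (strain Sprague-Dawley) for inhibition, with Rattus norvegicus as the target (a lower number here means that less compound is needed, a higher number that more compound is needed for the effect), compound 1 `CCc1cccc2c(=O)c(-c3nn[nH]n3)c[nH]c12` gives only a limit, > 25 mg/kg, and no number. Compound 2 `O=C(O)c1cnc2c(F)cccc2c1O` likewise gives only a limit in this assay, > 100 mg/kg. Both values shown are therefore limits, one at the limit of > 25 mg/kg in this assay, at which 1 of the 2 values shown sits, and one at the limit of > 100 mg/kg in this assay, at which 1 of the 2 values shown sits, so compound 1 cannot be placed above or below compound 2 on the numbers shown, and no step between measured compounds is available.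

Compound 3 `O=c1c(-c2nn[nH]n2)c[nH]c2ccccc12` differs from compound 1 by hydrogen in place of ethyl on an aromatic carbon, the change sitting on an aromatic carbon of a six-membered aromatic ring of carbon only, part of a fused or bridged system of two rings. Within the data shown here, with no measured step to lean on, the step from compound 1 to compound 3 is expected to be none beyond the scatter, a step that the limit leaves unreadable from compound 1 to compound 3, and compound 3 is most likely to return a limit as well. Compound 3 is estimated at 50 mg/kg in this assay, with a range from 20 mg/kg to 200 mg/kg.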

Compound 3, minimum effective dose: > 20 mg/kg
Compound 3 ended at the assay's limit; the forecaster's own chance of this, stated with the estimate: 70%; the middle value does not contradict the limit.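

In this assay compound 3 gives only a limit, > 20 mg/kg. Compound 1 also gives only a limit, > 25 mg/kg, so no step can be read between compound 1 and compound 3. On these data alone, whether hydrogen in place of ethyl changes the minimum effective dose remains open.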